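This account rests on a few compounds, and the source may have more. Where it says the series, first, only, none or still open, it means among the compounds named here.

Measured compounds:
compound 1 `C#CCSc1nc(NCCC#N)c2ccncc2n1` – > 80000 nM
compound 2 `C#CCSc1nc(Nc2ccc(F)cc2)c2ccncc2n1` – 15800 nM
compound 3 `C#CCSc1nc(Nc2cccc(Cl)c2)c2ccncc2n1` – 2190 nM

In a functional assay on MGC-803 cells (Homo sapiens) for inhibition, read by MTT assay, with a stated time of 72 h (a higher number here means a weaker inhibitor, a lower number a stronger inhibitor), compound 1 gives only a limit, (the limit of > 80000 nM in this assay, at which 1 of the 3 values shown sits). Compound 2 stands highest of the two numbers; its nearest neighbour is compound 3, with a 7.2-fold lower number from compound 2 to compound 3 (0.86 log units; beyond the scatter). Compound 4 `C#CCSc1nc(Nc2ccc(OC)cc2)c2ccncc2n1` is not yet measured. It differs from compound 2 by methoxy in place of fluoro on an aromatic carbon, the new group sitting para to a large group. Of the measured steps only the exchange of one ring substituent for another, a 7.2-fold lower number from compound 2 to compound 3 (0.86 log units; beyond the scatter), bears on this change; the steps of an at least 5.0-fold lower number from compound 1 to compound 2 (0.70 log units; beyond the scatter) and an at least 36-fold lower number from compound 1 to compound 3 (1.56 log units; beyond the scatter) replace the chain by a ring and say less. A modest step in this assay, in either direction, is therefore expected. For compound 4 the estimate is 10000 nM, within 3000 nM to 40000 nM, an expected step of a 1.6-fold lower number from compound 2 to compound 4 (0.20 log units; within the scatter).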

Compound 4, half-maximal inhibitory concentration: > 80000 nM
Compound 4: only a limit was reported; the forecaster's own chance of this, stated with the estimate: 10%; middle value at least 8.0-fold (0.90 log units) away from the limit.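

In this assay, methoxy in place of fluoro gives an at least 5.0-fold higher number from compound 2 to compound 4 (0.70 log units; beyond the scatter). The earlier compounds shown here showed a ring on the nitrogen only as a gain over the 2-cyanoethyl chain, whereas this change on the carbon para to a large group shows that the ring alone does not secure activity. Compound 4 gives only a limit, and it joins compound 1 there: the limit of > 80000 nM in this assay, at which 2 of the 4 values shown sit.

On these data alone, whether an amine or a hydroxy group on this carbon would keep activity stays open. So does the effect of methoxy at the ring position that carries chloro in compound 3.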